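The source may hold more compounds than are shown below. What is called first, only, known or untested is meant among the compounds shown, and "the series" means these compounds.

The series shares one core, seen in compound 1 `Cc1ccc(Cl)cc1Nc1nc(C(F)(F)F)ccc1CNC(=O)C(C)c1ccc(NS(C)(=O)=O)c(F)c1`, compound 2 `CC(C(=O)NCc1ccc(C(F)(F)F)nc1N1CCC(C)(C)CC1)c1ccc(NS(C)(=O)=O)c(F)c1` and compound 3 `CC(C(=O)NCc1ccc(C(F)(F)F)nc1N1CCC(C(=O)c2ccc(F)cc2)CC1)c1ccc(NS(C)(=O)=O)c(F)c1`; the compounds differ in the group on the aromatic carbon of that core. In a functional assay on CHO-K1 cells for antagonist activity at transient receptor potential cation channel subfamily V member 1 (Homo sapiens), read by FLIPR (on this read-out higher numbers stand for weaker inhibition and lower numbers for stronger inhibition), compound 1 gives 14 nM. For the measured compounds named here, compound 2 gives 0.3 nM in this assay, and the only single-point step in the set, a 47-fold lower number from compound 1 to compound 2 (1.67 log units; beyond the scatter), marks the exchange of the (5-chloro-2-methylphenyl)amino group for the 4,4-dimethylpiperidin-1-yl ring. Going by the values given here, compound 3 gives 3.9 nM in this assay and stands second highest of the three numbers, nearer to compound 1 than to compound 2; no single step links compound 2 and compound 3, but their values show that the ring carrying the (4-fluorophenyl)carbonyl group gives the higher number.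

Compound 4 `CCCCOC1CCN(c2nc(C(F)(F)F)ccc2CNC(=O)C(C)c2ccc(NS(C)(=O)=O)c(F)c2)CC1` is not yet measured. Its change from compound 3 is butoxy in place of (4-fluorophenyl)carbonyl on a saturated ring carbon. Among the compounds with values here, no measured step touches this position, so the step from compound 1 to compound 2 bears on it only indirectly, by showing that the group on the aromatic carbon sets the range of the numbers. The values of compound 2 and compound 3 point to a substituent without a ring on the saturated ring carbon going with a lower number. A moderate downward step, a 3.3-fold lower number from compound 3 to compound 4 (0.51 log units; beyond the scatter), is therefore expected in this assay. Compound 4 is estimated at 1.2 nM, with a range from 0.3 nM to 5 nM.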

Compound 4, inhibition constant: 3.5 nM
The estimate for compound 4 lay 2.9-fold (0.46 log units) below the measured number; low and high end bracket the measured number.
By their numbers in this assay, from the lowest: compound 2; then compounds 4 and 3 (each within the scatter of the next); then compound 1.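

In this assay, the exchange of (4-fluorophenyl)carbonyl for butoxy on the saturated ring carbon gives a 1.1-fold lower number from compound 3 to compound 4 (0.05 log units; within the scatter), so the two groups cannot be told apart here, although butoxy has no ring and fewer heavy atoms. Removing the aromatic ring from this substituent therefore does not close the gap to the unbranched-chain-free 4,4-dimethylpiperidin-1-yl analogue: the series still shows a 12-fold higher number from compound 2 to compound 4 (1.07 log units; beyond the scatter), and this large step sets the butoxy-bearing group clearly apart from the group of compound 2. For the compounds shown here, the butoxy-bearing group also retains an advantage over the (5-chloro-2-methylphenyl)amino group, with a 4.0-fold lower number from compound 1 to compound 4 (0.60 log units; beyond the scatter), a modest step that is smaller than the one from compound 1 to compound 2 and is still beyond the scatter.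

From the compounds shown here alone, whether a methoxy group, a longer chain such as hexyloxy, an amine or a carboxylic acid on this saturated ring carbon would read apart from butoxy remains open. The data on hand offer no measurement that explains why butoxy and (4-fluorophenyl)carbonyl read alike.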